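Notes on compounds 1 to 4 in the cell assay

The source may hold more compounds than are shown below. What is called first, only, known or untested is meant among the compounds shown, and "the series" means these compounds.

Measured so far in a functional assay on HT-22 cells (Mus musculus), read by MTT assay, with stated times of 2 h, 20 h and 4 h; on this read-out lower numbers stand for an effect already at smaller amounts and higher numbers for an effect only at larger amounts of compound:
compound 1 `CCOC(=O)C(CO)NC(=O)/C=C(C)/C=C/C1(O)C(C)=CC(=O)CC1(C)C` gives 13600 nM
compound 2 `CCCCC/C=C/C/C=C/CCCCCCCC(=O)NC(C(=O)OCC)c1nnn[nH]1` gives 11300 nM
compound 3 `CCCCCCCCCCCCCCCCCC(=O)NCCCCCC(=O)OCC(O)C1OC(=O)C(O)=C1O` gives 1800 nM

Compound 3 stands lowest of the three numbers in this assay. Its gap to compound 2, the nearest, lies beyond the usual scatter, as does its gap to compound 1, the furthest; on these three numbers compound 3 is thus the most potent of the set. The three measured compounds share no common scaffold, so no gap between any two of them can be read as a single structural change.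

Compound 4 `CCCCC/C=C\C/C=C\CCCCCCCC(=O)NCCCCCC(=O)OCC(O)C1OC(=O)C(O)=C1O` is not yet measured. It differs from compound 3 in one place: deca-1,4-dien-1-yl in place of decyl on a saturated chain carbon, seven bonds along the chain from a carbonyl carbon. Going by the values given here, nothing among the measured compounds isolates this change; compound 2 also carries a diene chain, but on a different scaffold, so its number says nothing about the change by itself. No step beyond the scatter is expected in this assay; the estimated step of a 1.2-fold higher number from compound 3 to compound 4 (0.09 log units; within the scatter) is small, with a slightly higher number as the more likely direction. Compound 4 is expected at 2200 nM, within a range of 700 nM to 7000 nM.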

Compound 4, half-maximal effective concentration: 6400 nM
The estimate for compound 4 lay 2.9-fold (0.46 log units) below the measured number, within the range that was stated.
By their numbers in this assay, from the lowest: compound 3; then compounds 4, 2 and 1 (each within the scatter of the next, the first and the last beyond it).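

In this assay, the form of the chain at this position matters even with its carbon count unchanged: deca-1,4-dien-1-yl in place of decyl gives a 3.6-fold higher number from compound 3 to compound 4 (0.55 log units; beyond the scatter). Going by these compounds alone, no ring, hydrogen-bond donor, hydrogen-bond acceptor or net charge enters with this change, so the pair isolates the two double bonds, which the earlier compounds could not do. Nothing measured here accounts for the step.

The compounds shown leave open how a longer saturated chain or a chain with a single double bond would stand against compound 3 and compound 4. They also leave open whether the same change has a similar effect on another core, as compound 2 has a diene chain but no saturated partner.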